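The source may report more compounds than this note shows. Statements on the series, on what has been measured and on what is new or still open speak of the compounds shown alone.

In an ADME assay on the whole organism (Rattus norvegicus, strain Sprague-Dawley) for pharmacokinetics, with a stated time of 6 h, at a dose of 10 mg/kg by the oral route (a lower number here means less compound in the circulation, a higher number more compound in the circulation at the dose given), compound 2 `Cc1cn2cc(-c3cc4ccc(N5CCN(C)CC5)cc4oc3=O)nc2cn1` gives < 10 ng.h/mL, which is a limit of the assay and not a number. Compound 1 `Cc1cn2nc(-c3cc(=O)n4cc(N5CCN(C)CC5)ccc4n3)cc2cn1` gives < 10 ng.h/mL, likewise a limit. Compound 3 `Cc1cn2cc(-c3cc4ccc(N5CCNCC5)cc4c(=O)o3)nc2c(C)n1` carries the added methyl but differs from compound 2 elsewhere too. Compound 3 gives a measured 280 ng.h/mL. Compound 4 `Cc1cn2cc(-c3cc4ccc(N5CCN(C)CC5)cc4oc3=O)nc2c(C)n1` differs from compound 2 by one change, methyl in place of hydrogen on an aromatic carbon. Within the data shown here, no measured pair isolates this change in this assay, so only a modest rise is expected, and a second limit remains possible. The expected step of an at least 3.0-fold higher number from compound 2 to compound 4 (0.47 log units; beyond the scatter) is small. For compound 4 the estimated value is 30 ng.h/mL, with an expected range of 10 ng.h/mL to 150 ng.h/mL.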

Compound 4, area under the concentration-time curve: 530 ng.h/mL
Estimate against measurement, compound 4: 18-fold (1.25 log units) below; the measured number lies above the stated range.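

In this assay, among these compounds, methyl in place of hydrogen on an aromatic carbon, next to the ring nitrogen, is the only change and gives an at least 53-fold higher number from compound 2 to compound 4 (1.72 log units; beyond the scatter). Among the compounds shown here, compound 3 also carries this methyl but differs elsewhere too, so only this pair isolates the change. Compound 2 stands at a limit of the assay and not a number, so the step has no upper bound: the limit of < 10 ng.h/mL in this assay, at which 2 of the 4 values shown sit.

As far as these compounds go, whether an ethyl group or an amine at this place would give a similar rise stays open. The values also cannot tell why the number rises.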